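A few compounds are considered here, and "the series" means these few. Any claim that something is new, unique, unknown or untested is made for them only; others in the source may bear on it.

Compound 1, `COc1ccc(S(=O)(=O)Nc2ccc(-c3nc4ccccc4o3)cc2)cc1`, gives in an assay on cells for inhibition of HSP60/HSP10 (Homo sapiens), with a stated time of 60 min (a higher number here means a weaker inhibitor, a lower number a stronger inhibitor), only a limit of the assay, > 100000 nM.
Compound 2, `O=S(=O)(Nc1ccc(-c2nc3ccccc3o2)cc1)c1cccc(C(F)(F)F)c1`, gives in this assay the value 57000 nM.
Compound 3, `CS(=O)(=O)Nc1ccc(-c2nc3ccccc3o2)cc1`, gives in this assay only a limit of the assay, > 100000 nM.

Compound 3 thus stands at the limit of this assay, not at a measured number, and it is not alone there: the limit of > 100000 nM in this assay, at which 2 of the 3 values shown sit. Going by the values given here, compound 4, `COc1cccc(S(=O)(=O)Nc2ccc(-c3nc4ccccc4o3)cc2)c1`, has not yet been measured. 3-methoxyphenyl in place of methyl on a sulfonyl sulfur The only measured step that swaps the group on the sulfonyl sulfur runs from compound 1 to compound 3: a step that the two limits leave unreadable from compound 1 to compound 3. Both ends of that step are limits, so neither its size nor its direction can be read, and it gives no guidance for compound 4. Compound 2, which carries a different six-membered ring on the same sulfur, gives a measured number, 57000 nM, so a ring at this position can at least bring the value inside the range of this assay. Compound 4 is therefore expected to remain a weak inhibitor, with an estimated value of 90000 nM, ranging from 30000 nM to 300000 nM, and a real chance that only a limit is reported again. The step from compound 3 to compound 4 is accordingly expected to be an at least 1.1-fold lower number from compound 3 to compound 4 (0.04 log units; that floor lies within the scatter).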

Compound 4, half-maximal inhibitory concentration: 80000 nM
Beside the measured number, compound 4's estimate is 1.1-fold (0.05 log units) above it; the measured number falls inside the stated range.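

With 3-methoxyphenyl on the sulfonyl sulfur, compound 4 joins compound 2 as a second compound with a measured number in this assay, so a number inside the range of this assay is not tied to the trifluoromethyl group of compound 2. Methoxy in place of trifluoromethyl on an aromatic carbon gives a 1.4-fold higher number from compound 2 to compound 4 (0.15 log units; within the scatter), so this change does not separate the two compounds. Measured against the compounds that sit at a limit, only floors can be read, an at least 1.2-fold lower number from compound 3 to compound 4 (0.09 log units; that floor lies within the scatter) and an at least 1.2-fold lower number from compound 1 to compound 4 (0.09 log units; that floor lies within the scatter), so neither replacing methyl nor exchanging 4-methoxyphenyl for 3-methoxyphenyl is shown to make a change beyond the scatter, although the true steps could be larger.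

As far as these compounds go, the step between compound 1 and compound 3 cannot be read, and much of this small series still gives no number to compare: the limit of > 100000 nM in this assay, at which 2 of the 4 values shown sit. Whether an amine or a carboxylic acid on the aromatic ring, or a longer chain in place of methyl on the sulfonyl sulfur, would lower the number clearly beyond the scatter remains open.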